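The source may report more compounds than this note shows. Statements on the series, on what has been measured and on what is new or still open speak of the compounds shown alone.

Measured in an ADME assay on MDCK cells (Canis lupus familiaris) for cytotoxicity, read by microscopy, with a stated time of 48 h; on this read-out lower numbers stand for higher toxicity in this test and higher numbers for lower toxicity in this test:
compound 1 `CSc1ccc(CN[C@@H]2C[C@H]3C[C@@H]([C@H]2C)C3(C)C)s1`: 25000 nM
compound 2 `C[C@H]1[C@H](NCc2ccc(Br)s2)C[C@H]2C[C@@H]1C2(C)C`: 43000 nM
compound 3 `C=C(C)c1csc(CN[C@@H]2C[C@H]3C[C@@H]([C@H]2C)C3(C)C)c1`: 25000 nM

Within the data shown here, compound 2 gives the highest of the three numbers, yet the only single-point step here, a 1.7-fold higher number from compound 1 to compound 2 (0.24 log units; within the scatter), lies within the scatter, and compound 3 matches compound 1, so the three cannot be told apart.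

Compound 4 `C[C@H]1[C@H](NCc2sccc2Br)C[C@H]2C[C@@H]1C2(C)C` differs from compound 2 by 3-bromothiophen-2-yl in place of 5-bromothiophen-2-yl on a saturated chain carbon bound to an amine nitrogen. Among the measured compounds shown here, no measured pair moves the bromine around the thiophene; the one step that touches the thiophene, a 1.7-fold higher number from compound 1 to compound 2 (0.24 log units; within the scatter), swaps the group and stays within the scatter. With nothing pointing either way, the expected step in this assay is a 1.1-fold lower number from compound 2 to compound 4 (0.03 log units; within the scatter), none beyond the scatter. Compound 4 is therefore estimated at 40000 nM, between 20000 nM and 80000 nM.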

Compound 4, minimum cytotoxic concentration: 50000 nM
Compound 4: middle estimate off by 1.3-fold (0.10 log units), on the low side, within the range that was stated.
By their numbers in this assay, from the lowest: compounds 1, 3, 2 and 4 (each within the scatter of the next).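

Exchanging 5-bromothiophen-2-yl for 3-bromothiophen-2-yl gives a 1.2-fold higher number from compound 2 to compound 4 (0.07 log units; within the scatter) in this assay, and this is the only pair shown that differs solely in where the bromine sits on the thiophene. With the same atoms joined differently, the step stays within the scatter, so this change does not separate compound 2 from compound 4 in this read-out. No evidence bears on this result.

Open, on these data alone, is whether an amine or a carboxylic acid in place of the bromine gives a step beyond the scatter. Also open, as far as these compounds go, is how changes to the shared core read in this assay.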